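The source may hold more compounds than are shown below. What is called first, only, known or untested is meant among the compounds shown, and "the series" means these compounds.

Compound 1 `COc1ccc(-c2nc3cccc(-c4cc(OC)c(OC)c(OC)c4)c3o2)cc1`: > 25000 nM (a limit)
Compound 2 `COc1cccc(-c2nc3cccc(-c4cc(OC)c(OC)c(OC)c4)c3o2)c1`: > 25000 nM (a limit)
Compound 3 `COc1ccc(-c2nc3cccc(-c4cc(OC)c(OC)c(OC)c4)c3o2)cc1OC`: 1300 nM

All three compounds were tested in a functional assay on U-251 cells (Homo sapiens) for antiproliferative activity, read by MTT assay, with a stated time of 48 h; a higher number here means a weaker inhibitor, a lower number a stronger inhibitor. Among the measured compounds shown here, compound 3, at 1300 nM, is the only one with an actual number. The values of compound 1 and compound 2 are limits of the assay and not numbers.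

Compound 4 `COc1ccc(-c2nc3cccc(-c4cc(OC)c(OC)c(OC)c4)c3o2)cc1F` changes 3,4-dimethoxyphenyl to 3-fluoro-4-methoxyphenyl, with fluoro in place of methoxy on an aromatic carbon. For the measured compounds named here, no measured step makes this exact swap. The nearest is an at least 19-fold lower number from compound 1 to compound 3 (1.28 log units; beyond the scatter), a large step in which methoxy replaces hydrogen on the carbon that carries fluoro in compound 4. The other step with the same change, on a different carbon, an at least 19-fold lower number from compound 2 to compound 3 (1.28 log units; beyond the scatter), is also large. Those steps suggest that compound 3 owes much of its activity to having both methoxy groups, so losing one should cost activity, though fluoro may retain some of it.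

The expected change is a 3.8-fold higher number from compound 3 to compound 4 (0.59 log units; beyond the scatter), towards a weaker inhibitor. The estimate for compound 4 is 5000 nM, with an expected range of 1200 nM to 25000 nM.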

Compound 4, half-maximal inhibitory concentration: 1700 nM
Beside the measured number, compound 4's estimate is 2.9-fold (0.47 log units) above it, within the range that was stated.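

In this assay, fluoro does the job of methoxy at this position, with a 1.3-fold higher number from compound 3 to compound 4 (0.12 log units; within the scatter), so activity on this scale does not depend on keeping this methoxy group. The earlier compounds shown here showed a gain only from adding methoxy, and that gain now also appears with fluoro in place of hydrogen, as an at least 14-fold lower number from compound 1 to compound 4 (1.16 log units; beyond the scatter), and with 3-fluoro-4-methoxyphenyl in place of 3-methoxyphenyl, as an at least 14-fold lower number from compound 2 to compound 4 (1.16 log units; beyond the scatter). Compound 1 and compound 2 each stand at a limit and not at a number, so these two steps give only a minimum size: the limit of > 25000 nM in this assay, at which 2 of the 4 values shown sit.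

On these data alone, it remains open how wide the choice of group at this carbon is, since chloro, hydroxyl or an amine could behave differently from fluoro and methoxy. As far as these compounds go, it is also open whether the remaining methoxy group of the 3-fluoro-4-methoxyphenyl can be exchanged in the same way.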